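The source may report more compounds than this note shows. Statements on the series, on what has been measured and on what is new or still open speak of the compounds shown alone.

Measured in a functional assay on HT-29 cells (Homo sapiens) for inhibition, read by luminescence and CellTiter-Glo, with a stated time of 10 h; a higher number here means that more compound is needed for the effect, a lower number that less compound is needed:

- Compound 1 `CN1C(=S)[C@H](NC(=O)c2n[nH]c(Cc3ccccc3)n2)COc2ncccc21`: > 10000 nM, a limit of the assay and not a number
- Compound 2 `Cc1cnc2c(c1)N(C)C(=S)[C@@H](NC(=O)c1n[nH]c(Cc3ccccc3)n1)CO2`: 144 nM

Within the data shown here, compound 2, at 144 nM, holds the only actual number so far, so there is no series of numbers to rank it in. Compound 3 `Cc1cnc2c(c1)N(C)C(=S)[C@H](NC(=O)c1n[nH]c(Cc3ccccc3)n1)CO2` changes nothing in its connectivity: the two compounds have the same atoms and bonds and differ only in configuration as drawn: 1 of 1 stereo elements differ; a stereocentre at a saturated ring carbon is drawn S in compound 2 and R in compound 3. The two compounds have the same atoms and bonds, and a stereocentre at a saturated ring carbon is drawn S in compound 2 and R in compound 3.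

Among the measured compounds shown here, no measured pair shows what such a switch does, so the expected size is a judgement. A large step towards weaker activity in this assay is expected, meaning a higher number. Compound 1, at > 10000 nM, shows that a limit result can occur here. For compound 3 the estimated value is 8000 nM, with an expected range of 1000 nM to 30000 nM. This estimate means an expected 56-fold higher number from compound 2 to compound 3 (1.74 log units; beyond the scatter).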

Compound 3, half-maximal effective concentration: 3400 nM
Beside the measured number, compound 3's estimate is 2.4-fold (0.37 log units) above it; measured number inside the range.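

In this assay, switching this one saturated ring carbon from S to R gives a 24-fold higher number from compound 2 to compound 3 (1.37 log units; beyond the scatter), so the spatial arrangement at this carbon matters even with the atoms and bonds unchanged: the fact that compounds 2 and 3 differ only in the configuration as drawn

Compound 3 also shows the effect of methyl in place of hydrogen on an aromatic carbon within the R series, which gives an at least 2.9-fold lower number from compound 1 to compound 3 (0.46 log units; beyond the scatter). This size is only a minimum because one end of the step is a limit and not a number: the limit of > 10000 nM in this assay, at which 1 of the 3 values shown sits.

From the compounds shown here alone, it remains open whether the methyl step would have a similar size in the S series. Going by these compounds, it is also open how an ethyl group, a methoxy group or a chlorine atom in place of that methyl would change the number.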